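This account rests on a few compounds, and the source may have more. Where it says the series, first, only, none or still open, it means among the compounds named here.

In an in vitro functional assay on HEK293-A cells for positive allosteric modulation of metabotropic glutamate receptor 5 (Homo sapiens), read by FLIPR and calcium flux (a lower number here means that less compound is needed, a higher number that more compound is needed for the effect), compound 1, `O=C1CC(c2nc(-c3cccc(F)c3)no2)CN1c1ccc(Cl)cc1`, gives 630 nM. Compound 2, `Cc1cccc(-c2noc(C3CC(=O)N(c4ccc(F)cc4)C3)n2)n1`, does not reach a number in this assay and returns only the limit of the method, > 10000 nM. Compound 3, `O=C1CC(c2nc(-c3cccc(Cl)c3)no2)CN1c1cccc(Cl)c1`, stands at the same limit in this assay, > 10000 nM, so its position is known only as a boundary and not as a value. For the measured compounds named here, two of the three results sit at that boundary (the limit of > 10000 nM in this assay, at which 2 of the 3 values shown sit), which leaves compound 1 as the single number in the group.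

Compound 4, `O=C1CC(c2nc(-c3cccc(Cl)c3)no2)CN1c1ccccc1Cl`, is built from the same atoms as compound 3: 2-chlorophenyl in place of 3-chlorophenyl on an amide-type nitrogen in a ring. Going by the values given here, since compound 3 carries only a limit, no measured step from it can be sized, and the data hold no step of this kind elsewhere. The expected step in this assay is a step that the limit leaves unreadable from compound 3 to compound 4, meaning no change beyond the boundary already seen. Compound 4 is therefore estimated in this assay at 15000 nM, within 4000 nM to 50000 nM, and most likely to be reported again as a limit.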

Compound 4, half-maximal effective concentration: > 10000 nM
Compound 4: a limit, no number; the forecaster's own chance of this, stated with the estimate: 75%; the middle value lies beyond the limit too.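

No step from compound 3 to compound 4 can be read, since both stand only at a limit in this assay: the limit of > 10000 nM in this assay, at which 3 of the 4 values shown sit.

The compounds shown leave open whether 2-chlorophenyl and 3-chlorophenyl on the amide-type nitrogen in a ring differ at all in this response.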